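Adding ethyl to the nitrogen of compound 3

The source may report more compounds than this note shows. Statements on the series, on what has been measured and on what is new or still open speak of the compounds shown alone.

Within the data shown here, in a functional assay on L1210 cells (Mus musculus) for inhibition (a lower number here means a stronger inhibitor, a higher number a weaker inhibitor), compound 3 `Cc1nc(O)c2cc(CNc3ccc(S(=O)(=O)c4ccccc4)cc3)ccc2n1` gives 14700 nM as the higher of the two numbers so far. Compound 2 `C#CCN(Cc1ccc2nc(C)nc(O)c2c1)c1ccc([N+](=O)[O-])c(C(F)(F)F)c1` gives 5000 nM as the lower number, and the gap lies beyond the scatter. Compound 1 `C#CCN(Cc1ccc2nc(C)nc(O)c2c1)c1ccccc1` reads > 6500 nM as a limit and not a number. Compound 4 `CCN(Cc1ccc2nc(C)nc(O)c2c1)c1ccc(S(=O)(=O)c2ccccc2)cc1` has ethyl in place of hydrogen on a nitrogen on an aromatic ring and awaits measurement. Among the measured compounds shown here, no measured pair isolates this change, so the expectation is loose. It leans on compound 2, whose nitrogen also carries a substituent, at 5000 nM in the same test. The expected step of a 2.1-fold lower number from compound 3 to compound 4 (0.32 log units; beyond the scatter) is modest, toward a stronger inhibitor. In this assay compound 4 is estimated at 7000 nM with 2500 nM to 20000 nM as its expected range.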

Compound 4, half-maximal inhibitory concentration: 660 nM
For compound 4 the middle estimate is 11-fold (1.03 log units) above the measured one, and the stated range ends above it.
By their numbers in this assay, from the lowest: compound 4; then compound 2; then compound 3.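

In this assay, the nitrogen on an aromatic ring proves highly sensitive to what it carries: ethyl in place of hydrogen gives a 22-fold lower number from compound 3 to compound 4 (1.35 log units; beyond the scatter). Among these compounds, until this pair, no measured step had separated the substituent on this nitrogen from changes elsewhere in the molecule. Nothing measured here explains why the number falls so far. From the compounds shown here alone, what a methyl group or a longer chain such as propyl would do on this nitrogen stays open. Also open, going by these compounds, is whether ethyl would give a similar step on compounds with other aromatic ring substituents.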